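The compounds below may be only part of what the source reports. "The series", "measured", "known", "first", "only" and "open" are said of these compounds alone.

Of the compounds shown here, three have been measured in a functional assay on HepG2 cells (Homo sapiens) for cytotoxicity, read by MTT assay, with a stated time of 72 h; on this read-out higher numbers stand for weaker inhibition and lower numbers for stronger inhibition. Compound 1 `CNC(=O)c1cc(Oc2ccc(NC(=O)c3nn(-c4ccccc4C(F)(F)F)c(=O)cc3C)cc2F)ccn1` gives only a limit of the assay, > 40000 nM. Compound 2 `CNC(=O)c1cc(Oc2ccc(NC(=O)c3nn(-c4cccc(F)c4)c(=O)cc3C)cc2F)ccn1` gives 10200 nM, and compound 3 `CNC(=O)c1cc(Oc2ccc(NC(=O)c3nn(-c4ccc(C)cc4)c(=O)cc3C)cc2F)ccn1` gives 10600 nM. The two finite numbers are close: the step of a 1.0-fold higher number from compound 2 to compound 3 (0.02 log units; within the scatter), and compound 3 thus holds the higher of the two numbers while sitting within the scatter of compound 2. The moves away from compound 1 were larger, as the steps of an at least 3.9-fold lower number from compound 1 to compound 2 (0.59 log units; beyond the scatter) and an at least 3.7-fold lower number from compound 1 to compound 3 (0.57 log units; beyond the scatter) show, though both rest on the limit described by the limit of > 40000 nM in this assay, at which 1 of the 3 values shown sits.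

The next compound, compound 4 `Cc1ccc(-n2nc(C(=O)Nc3ccc(Oc4ncnc5sccc45)c(F)c3)c(C)cc2=O)cc1`, changes a different part of the molecule: a group of 9 heavy atoms (6 carbon, 2 nitrogen, 1 sulfur; one five-membered aromatic ring with 1 hetero atom, one six-membered aromatic ring with 2 hetero atoms) in place of a group of 10 heavy atoms (7 carbon, 2 nitrogen, 1 oxygen; one six-membered aromatic ring with 1 hetero atom), on an oxygen on an aromatic ring. All three measured steps altered the aryl group on the aromatic nitrogen and left this oxygen-linked group untouched, so none of them speaks directly to the change from compound 3 to compound 4. Without a comparable step, the expectation is that the number stays near that of compound 3, with a wide range in either direction, and the step of a 1.2-fold lower number from compound 3 to compound 4 (0.07 log units; within the scatter) is therefore estimated to stay within the scatter. Compound 4 is expected to give about 9000 nM, most likely between 2000 nM and 40000 nM, in this assay.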

Compound 4, half-maximal inhibitory concentration: > 40000 nM
Compound 4 gave a limit, no number (the forecaster's own chance of this, stated with the estimate: 25%); at least 4.4-fold (0.64 log units) between middle value and limit.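

Among the compounds shown here, with the 4-methylphenyl group on the aromatic nitrogen held fixed, the first change on an oxygen on an aromatic ring gives, in this assay, an at least 3.7-fold higher number from compound 3 to compound 4 (0.57 log units; beyond the scatter). For the compounds shown here, a higher number here stands for weaker inhibition, so this oxygen-linked part of the molecule can move the read-out beyond the scatter, which the earlier steps on the aromatic nitrogen could not show. Compound 4 gives a limit and not a number, so the step has a known minimum but no known size: the limit of > 40000 nM in this assay, at which 2 of the 4 values shown sit.

This single change swaps the 2-(methylcarbamoyl)pyridin-4-yl group for a group with a five-membered and a six-membered aromatic ring, brings in sulfur and removes the hydrogen-bond donor all at once, and the compounds shown cannot separate these features. They also leave open how a pyridin-4-yl group carrying an amine or a carboxylic acid in place of the methylcarbamoyl group would read, and whether the new oxygen-linked group would give the same kind of result alongside the 3-fluorophenyl group of compound 2.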